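Acylhydrazone versus oxadiazole: removing the para-chloro substituent

The source may report more compounds than this note shows. Statements on the series, on what has been measured and on what is new or still open speak of the compounds shown alone.

Measured compounds:
compound 1 `COc1ccc(OC)c(/C=C/c2nnc(Nc3ccc(Cl)cc3)o2)c1`: 20700 nM
compound 2 `COc1ccc(OC)c(/C=C/C(=O)N/N=C/c2ccc(Cl)cc2)c1`: 74.3 nM

Two compounds share the dimethoxystyryl fragment and the chlorophenyl end. In a functional assay on MCF7 cells (Homo sapiens) for antiproliferative activity, read by sulforhodamine B assay, with a stated time of 48 h (a higher number here means a weaker inhibitor of growth, a lower number a stronger inhibitor of growth), compound 1 gives 20700 nM, while compound 2 gives 74.3 nM. Compound 2 thus holds the lower of the two numbers, the gap to compound 1 lying well beyond the scatter; as the two differ in more than one place, nothing further is read from this pair.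

Compound 3 `COc1ccc(OC)c(/C=C/C(=O)N/N=C/c2ccccc2)c1` is the next point in the series. The change from compound 2 to compound 3 is hydrogen in place of chloro on an aromatic carbon, para to a large group, on the six-membered aromatic ring of carbon only.

Among the compounds with values here, no step between measured compounds reports such a change, so the size of the step in this assay is unknown from the data. A modest step towards a higher number is expected, probably near the edge of the scatter rather than far beyond it. Compound 3 is thus estimated at 160 nM (range 50 nM to 500 nM), an expected step of a 2.2-fold higher number from compound 2 to compound 3 (0.33 log units; beyond the scatter).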

Compound 3, concentration for 50% growth inhibition: 3790 nM
Compound 3: middle estimate off by 24-fold (1.37 log units), on the low side; measured number above the stated range.
By their numbers in this assay, from the lowest: compound 2; then compound 3; then compound 1.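

Replacing chloro with hydrogen on the aromatic carbon, para to a large group, gives a 51-fold higher number from compound 2 to compound 3 (1.71 log units; beyond the scatter) in this assay, so a single chlorine atom separates these two results. Within the data shown here, the earlier pair differed in more than one place and could not be assigned to any one position; this step is the first to isolate a single site, and it shows that this site is highly sensitive to this change. The data at hand offer nothing that explains why the loss of chloro has so large an effect here.

Going by these compounds, whether this sensitivity is specific to chloro or extends to other groups remains open: fluoro, bromo, methyl, methoxy or an amine on the same aromatic carbon would help distinguish between these readings. On these data alone, it is also open whether the step carries over to the core of compound 1, which bears a 4-chlorophenyl group as well, and the phenyl counterpart of compound 1 would test this.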